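This account rests on a few compounds, and the source may have more. Where it says the series, first, only, none or still open, it means among the compounds named here.

Compound 1, with the structure `CCC(C(=O)N1CCN(c2cccc(Cl)c2)CC1)N1C(=O)CCC1=O`, was tested in a functional assay on the whole organism (strain Swiss) with Mus musculus as the target, in the maximal electroshock model, with a stated time of 2 h, at a dose of 300 mg/kg by the intraperitoneal route (on this read-out higher numbers stand for a stronger effect at the one dose given and lower numbers for a weaker effect), where compound 1 gives 25%. Going by the values given here, on the numbers measured so far this is the lowest of the two. The other measured compound, compound 2, with the structure `CC(C(=O)N1CCN(c2ccccc2C(F)(F)F)CC1)N1C(=O)CCC1=O`, gives 75% in this assay, a number far above that of compound 1 and well beyond the usual scatter of such readings. The structures of compound 1 and compound 2 differ in more than one place, so no single step can be read from this pair.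

Compound 3, with the structure `CCC(C(=O)N1CCN(c2ccccc2F)CC1)N1C(=O)CCC1=O`, has not yet been measured. It differs from compound 1 in one place only: 2-fluorophenyl in place of 3-chlorophenyl on an amine nitrogen in a ring. Among the compounds with values here, no measured pair shows exactly this change, so the expectation rests on the spread of the two known numbers. The step from compound 1 to compound 3 is expected to be a rise, a number 25 percentage points higher from compound 1 to compound 3 (beyond the scatter), larger than the scatter but uncertain in size. Compound 3 is therefore estimated to give about 50% in this assay, within a range from 20% to 85%.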

Compound 3, a percentage reported as activity, at one dose (the size of the read-out at that dose, not a potency): 0%
Estimate against measurement, compound 3: 50 percentage points above; measured number outside the range, below it.
By their numbers in this assay, from the lowest: compound 3; then compound 1; then compound 2.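

In this assay the swap of 3-chlorophenyl for 2-fluorophenyl on an amine nitrogen in a ring gives a number 25 percentage points lower from compound 1 to compound 3 (beyond the scatter) and takes the read-out to the lowest number seen so far. This shows that the aryl group at this nitrogen is not a silent part of the molecule: the two groups match in heavy-atom count, in their single six-membered aromatic ring of carbon only, and in having no hydrogen-bond donors, acceptors or net charge, yet the read-out still falls. No measurement shown here explains this fall.

The step changes both the halogen and where it sits on the ring, so it cannot say which of the two matters, and compound 2 differs from compound 1 and compound 3 in more than one place, so it cannot settle the question. A 2-chlorophenyl or a 3-fluorophenyl group at this nitrogen would pull the two changes apart, while a plain phenyl group would show what the ring does with no halogen at all.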